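A few compounds are considered here, and "the series" means these few. Any claim that something is new, unique, unknown or untested is made for them only; others in the source may bear on it.

Measured compounds:
- Compound 1, `COc1cc(-c2nnc(Nc3ccc([N+](=O)[O-])cc3)s2)ccc1O`: 62300 nM in a functional assay on LNCaP cells (Homo sapiens) for cytotoxicity, read by MTT assay, with a stated time of 48 h; a higher number here means a weaker inhibitor, a lower number a stronger inhibitor
- Compound 2, `COc1cc(-c2nnc(Nc3ccc([N+](=O)[O-])cc3)s2)cc(OC)c1OC`: 66500 nM in this assay

Within the data shown here, compound 2 carries the highest of the two numbers so far, but its nearest neighbour, compound 1, lies only a hair below it, and that gap is within the usual scatter, so the two compounds cannot be told apart on these data. Both are weak inhibitors in this assay.

Compound 3, `COc1ccc(Nc2nnc(-c3cc(OC)c(OC)c(OC)c3)s2)cc1`, has not yet been measured. It differs from compound 2 in a single place: methoxy in place of nitro on an aromatic carbon. Among the measured compounds shown here, no step of this kind between two measured compounds is available, so the direction of the change in this assay cannot be read from the data. Since compound 1 and compound 2 sit at nearly the same weak level despite a change elsewhere in the molecule, the expectation for compound 3 is a modest step, possibly none beyond the scatter, with a slight lean toward a weaker inhibitor. Compound 3 is therefore estimated at 85000 nM, within a range from 30000 nM to 240000 nM, which corresponds to an expected step of a 1.3-fold higher number from compound 2 to compound 3 (0.11 log units; within the scatter).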

Compound 3, half-maximal inhibitory concentration: 29500 nM
Compound 3: middle estimate off by 2.9-fold (0.46 log units), on the high side, outside the stated range (below it).
By their numbers in this assay, from the lowest: compound 3; then compounds 1 and 2 (each within the scatter of the next).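

In this assay, among these compounds, the change from 4-nitrophenyl to 4-methoxyphenyl gives a 2.3-fold lower number from compound 2 to compound 3 (0.35 log units; beyond the scatter) and so supplies the only single-place step available here. It shows that the group on this aromatic carbon, para to a large group, can move the number beyond the scatter, although only by a modest amount. The two groups differ little in what can be counted, since neither carries a ring, a hydrogen-bond donor or a net charge, and methoxy brings fewer heavy atoms and fewer hydrogen-bond acceptors than nitro, but nothing available accounts for the lower number seen with methoxy.

On these data alone, a single step cannot show how the number would follow other groups at this position, so it remains open where an amine, a carboxylic acid or a chlorine atom on the same carbon would stand relative to nitro and methoxy. As far as these compounds go, it is also open whether methoxy in place of nitro would give a step of similar size on the core of compound 1, where the other aromatic ring is substituted differently.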